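Adding Fluoro to Compound 2: What to Expect

This account rests on a few compounds, and the source may have more. Where it says the series, first, only, none or still open, it means among the compounds named here.

Compound 1 `N#Cc1cc(O)cc(OC(=O)N2CCC(C(c3ccccc3)c3ccccc3)CC2)c1`: > 1000 nM
Compound 2 `N#Cc1cccc(OC(=O)N2CCC(C(c3ccccc3)c3ccccc3)CC2)c1`: > 1000 nM
Compound 3 `N#Cc1cccc(OC(=O)N2CCC(Cc3ccccc3)CC2)c1`: 44.7 nM

In an assay on isolated protein for inhibition of Fatty-acid amide hydrolase 1 (Rattus norvegicus), read by fluorescence (on this read-out lower numbers stand for stronger inhibition and higher numbers for weaker inhibition), compound 2 reaches only a limit, > 1000 nM, not a number. Compound 1 likewise sits at a limit, > 1000 nM. Compound 3 gives 44.7 nM. Because two of the three values stand at the same limit (the limit of > 1000 nM in this assay, at which 2 of the 3 values shown sit), the step that the two limits leave unreadable from compound 1 to compound 2 cannot be read, whereas an at least 22-fold lower number from compound 2 to compound 3 (1.34 log units; beyond the scatter) shows that taking away one phenyl changes the number a great deal. Compound 4 `N#Cc1cc(F)cc(OC(=O)N2CCC(C(c3ccccc3)c3ccccc3)CC2)c1` differs from compound 2 by fluoro in place of hydrogen on an aromatic carbon and keeps both phenyl groups. Going by the values given here, no measured step involves fluoro, so the expectation rests on compound 2 standing at its limit. The expected change a step that the limit leaves unreadable from compound 2 to compound 4 is none beyond the scatter. Compound 4 is therefore estimated at 3000 nM, between 800 nM and 20000 nM.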

Compound 4, half-maximal inhibitory concentration: > 1000 nM
Compound 4 was reported as a limit (the forecaster's own chance of this, stated with the estimate: 70%); the middle value lies beyond the limit too.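

In this assay compound 4 stands at a limit, > 1000 nM and not a number, so the steps from compound 1 and compound 2 to compound 4 cannot be read. On these data alone, whether fluoro in place of hydrogen changes inhibition at all remains open.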